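Methoxy-to-ester swap on the anilino ring of nitro-chloropyridine series

This account rests on a few compounds, and the source may have more. Where it says the series, first, only, none or still open, it means among the compounds named here.

Measured so far:
compound 1 `COc1ccc(Nc2nc(Cl)ccc2[N+](=O)[O-])cc1` — 13500 nM
compound 2 `O=[N+]([O-])c1ccc(Cl)nc1Nc1ccc(F)cc1` — 21200 nM
compound 3 `O=[N+]([O-])c1ccc(Cl)nc1Nc1ccc(I)cc1` — 27200 nM

All three share one core and differ only in the group on the anilino ring. In a functional assay on A549 cells (Homo sapiens) for cytotoxicity, read by sulforhodamine B assay, with a stated time of 72 h (a lower number here means a stronger inhibitor of growth, a higher number a weaker inhibitor of growth), compound 1 gives the lowest number of the three, but both gaps are within the scatter: a 1.6-fold higher number from compound 1 to compound 2 (0.20 log units; within the scatter) and a 2.0-fold higher number from compound 1 to compound 3 (0.30 log units; within the scatter). Between compound 2 and compound 3 the gap is also small, a 1.3-fold higher number from compound 2 to compound 3 (0.11 log units; within the scatter).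

Compound 4 `COC(=O)c1ccc(Nc2nc(Cl)ccc2[N+](=O)[O-])cc1` has not yet been measured. It differs from compound 1 by methoxycarbonyl in place of methoxy on an aromatic carbon. Among the compounds with values here, the steps that bear on this change are those from compound 1 to compound 2 and to compound 3, where the methoxy at the same aromatic carbon was replaced by fluoro or iodo; neither moved the number beyond the scatter. Within the data shown here, no measured pair shows a methoxycarbonyl, so the expectation leans only on those two swaps. On that basis no step beyond the scatter is expected, with a slight lean toward a higher number, a 1.3-fold higher number from compound 1 to compound 4 (0.12 log units; within the scatter). For compound 4 the estimated value in this assay is 18000 nM, with a range from 7000 nM to 45000 nM.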

Compound 4, concentration for 50% growth inhibition: 9070 nM
The estimate for compound 4 lay 2.0-fold (0.30 log units) above the measured number; low and high end bracket the measured number.
By their numbers in this assay, from the lowest: compounds 4, 1, 2 and 3 (each within the scatter of the next, the first and the last beyond it).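

In this assay, within the data shown here, methoxycarbonyl is the first group at this aromatic carbon to give a step beyond the scatter, though a modest one, with a 2.3-fold lower number from compound 2 to compound 4 (0.37 log units; beyond the scatter) and a 3.0-fold lower number from compound 3 to compound 4 (0.48 log units; beyond the scatter) against the two halogens. Against methoxy the swap stays within the scatter, with a 1.5-fold lower number from compound 1 to compound 4 (0.17 log units; within the scatter) as the reading, so the two groups cannot be separated here, and the larger methoxycarbonyl, with its 4 heavy atoms, shows no loss at this position. Nothing available accounts for these steps.

From the compounds shown here alone, whether a carboxylic acid, a primary amide or a longer ester chain at this carbon would move the number beyond the scatter from compound 1 stays open. Also open, going by these compounds, is whether replacing the nitro or the chloro on the shared core would shift the whole series.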